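Imidazole in Place of Pyridine on an Adenosine Hydrazone

A few compounds are considered here, and "the series" means these few. Any claim that something is new, unique, unknown or untested is made for them only; others in the source may bear on it.

Measured so far:
compound 1 `Nc1nc(N/N=C/c2cccnc2Cl)nc2c1ncn2[C@@H]1O[C@H](CO)[C@@H](O)[C@H]1O` — 4.6 nM
compound 2 `Nc1nc(N/N=C/c2ccc(-c3ccccc3)cc2)nc2c1ncn2[C@@H]1O[C@H](CO)[C@@H](O)[C@H]1O` — 7860 nM

Among the compounds with values here, in an assay on CHO-K1 cells for displacement of a labelled ligand from adenosine receptor A1 (Homo sapiens), read by scintillation counting, with a stated time of 60 min (a lower number here means a stronger inhibitor, a higher number a weaker inhibitor), compound 1 gives 4.6 nM, the lowest of the two numbers known. Compound 2 gives 7860 nM, and the gap between them lies well beyond the scatter. Compound 3 `CCCCc1nc(/C=N/Nc2nc(N)c3ncn([C@@H]4O[C@H](CO)[C@@H](O)[C@H]4O)c3n2)c(Cl)[nH]1` has not been measured. It differs from compound 1 in one place: 2-butyl-5-chloro-1H-imidazol-4-yl in place of 2-chloropyridin-3-yl on a carbon with a double bond to nitrogen. Within the data shown here, no single-place step between measured compounds is available, so the size of this change can only be guessed; the values of compound 2 show that another group at this place can give a far higher number. The step of an 8.7-fold higher number from compound 1 to compound 3 (0.94 log units; beyond the scatter) is expected to go toward a weaker inhibitor, beyond the scatter. Compound 3 is estimated at 40 nM, within 5 nM to 400 nM.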

Compound 3, inhibition constant: 12 nM
Estimate against measurement, compound 3: 3.3-fold (0.52 log units) above; the range from low to high includes it.
By their numbers in this assay, from the lowest: compound 1; then compound 3; then compound 2.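

In this assay the swap of 2-chloropyridin-3-yl for 2-butyl-5-chloro-1H-imidazol-4-yl gives a 2.6-fold higher number from compound 1 to compound 3 (0.42 log units; beyond the scatter) and is thus a modest step. On this carbon with a double bond to nitrogen, a five-membered aromatic ring bearing a butyl chain therefore stays far closer to compound 1 than the group of compound 2 does. Nothing measured here accounts for the step. The compounds shown leave open what the butyl chain and the chlorine each contribute. An imidazole with a methyl group in place of butyl, or with hydrogen in place of chlorine, would separate the two.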